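Carbamate inhibitors: a nitrile in place of a methyl

The source may hold more compounds than are shown below. What is called first, only, known or untested is meant among the compounds shown, and "the series" means these compounds.

Measured compounds:
compound 1, `Cc1ccc(-c2cccc(OC(=O)NC3CCCCC3)c2)cc1`: 155 nM
compound 2, `O=C(NC1CCCCC1)Oc1cccc(-c2ccc(F)cc2)c1`: 65 nM
compound 3, `Cc1cccc(-c2cccc(OC(=O)NC3CCCCC3)c2)c1`: 61.8 nM

In an assay on cell membranes for binding affinity to Fatty-acid amide hydrolase 1 (Rattus norvegicus) (a lower number here means a stronger inhibitor, a higher number a weaker inhibitor), compound 1 gives 155 nM, the highest of the three numbers; compound 2 and compound 3 both lie beyond the scatter below it. The unmeasured compound 4, `N#Cc1cccc(-c2cccc(OC(=O)NC3CCCCC3)c2)c1`, differs from compound 1 by 3-cyanophenyl in place of 4-methylphenyl on an aromatic carbon, placed on an aromatic carbon. For the measured compounds named here, two measured steps bear on this change. Changing the substituent itself gave a 2.4-fold lower number from compound 1 to compound 2 (0.38 log units; beyond the scatter), and moving the methyl from the 4-position to the 3-position gave a 2.5-fold lower number from compound 1 to compound 3 (0.40 log units; beyond the scatter). Compound 4 combines a new substituent with the 3-position, so a modest step to a lower number in this assay is expected, of the order seen in those two steps rather than larger, since compound 2 and compound 3 are within the scatter of each other. The expected step is a 2.4-fold lower number from compound 1 to compound 4 (0.38 log units; beyond the scatter). For compound 4 the estimate is 65 nM, with a range from 25 nM to 170 nM.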

Compound 4, half-maximal inhibitory concentration: 33.9 nM
The estimate for compound 4 lay 1.9-fold (0.28 log units) above the measured number, within the range that was stated.
By their numbers in this assay, from the lowest: compounds 4, 3 and 2 (each within the scatter of the next); then compound 1.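

In this assay, the change to 3-cyanophenyl gives a step beyond the scatter (a 4.6-fold lower number from compound 1 to compound 4 (0.66 log units; beyond the scatter)), so a nitrile is accepted on this ring in place of the methyl without loss. At this position, however, the nitrile cannot be told apart from the methyl (a 1.8-fold lower number from compound 3 to compound 4 (0.26 log units; within the scatter)), and 3-cyanophenyl cannot be told apart from 4-fluorophenyl (a 1.9-fold lower number from compound 2 to compound 4 (0.28 log units; within the scatter)). Compounds 2, 3 and 4 therefore form one group within the scatter of the next, and only compound 1, with its 4-methylphenyl, stands apart from all three.

The compounds shown leave open whether a 4-cyanophenyl group would fall with compound 1 or with compound 4, and whether 3-aminophenyl or 3-carboxyphenyl would keep the number of compound 4. No measurement here accounts for any of these steps.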